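Trimming an ethyl to a methyl on a shared core

The source may report more compounds than this note shows. Statements on the series, on what has been measured and on what is new or still open speak of the compounds shown alone.

Of the compounds shown here, two with the same core have been tested so far. Compound 1 `COc1nc2nc(C(=O)c3ccccc3)cn2c(C)c1CC1CC1` was measured in a functional assay on the whole organism with Rattus norvegicus as the target (a higher number here means that more compound is needed for the effect, a lower number that less compound is needed), and gives 10 mg/kg. Compound 2 `C=CCc1c(OC)nc2nc(C(=O)c3ccccc3)cn2c1CC` carries an allyl group and an ethyl group on the core in place of the cyclopropylmethyl and methyl groups of compound 1. In this assay compound 2 gives 10 mg/kg. Compound 2 thus stands level with compound 1 at the digits shown; the two values lie within the scatter of each other, so no order between them can be read.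

Compound 3 `C=CCc1c(OC)nc2nc(C(=O)c3ccccc3)cn2c1C` is the next compound to be measured in this assay. It differs from compound 2 in one place: hydrogen in place of methyl on a saturated chain carbon bound to an aromatic carbon. Compound 1 already carries a methyl at this position and gives the same value as compound 2, so little change is expected. The step from compound 2 to compound 3 is estimated as no change at the digits printed from compound 2 to compound 3 (within the scatter), no change beyond the scatter. The estimate for compound 3 is 10 mg/kg, with a range from 4 mg/kg to 25 mg/kg.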

Compound 3, minimum effective dose: 5 mg/kg
For compound 3 the middle estimate is 2.0-fold (0.30 log units) above the measured one; the measured number falls inside the stated range.
By their numbers in this assay, from the lowest: compounds 3, 1 and 2 (each within the scatter of the next).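

Ethyl to methyl, on a saturated chain carbon bound to an aromatic carbon, can now be read as a single change: in this assay it gives a 2.0-fold lower number from compound 2 to compound 3 (0.30 log units; within the scatter), so the two groups cannot be told apart at this place. Vinyl in place of cyclopropyl, on a saturated chain carbon bound to an aromatic carbon, gives a 2.0-fold lower number from compound 1 to compound 3 (0.30 log units; within the scatter), so this second single change cannot be told from the scatter either. Nothing at hand speaks to what lies behind these numbers.

The compounds shown say nothing about how a longer chain such as butyl, or an amine, would read at either place. They also leave open whether either change would reach beyond the scatter on a different core.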